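A few compounds are considered here, and "the series" means these few. Any claim that something is new, unique, unknown or untested is made for them only; others in the source may bear on it.

Measured compounds:
- compound 1 `CN(C)C(=O)CN1CCC(c2cc3c(-c4ccc(=O)n(C5CCC5)c4)ccnc3[nH]2)CC1`: < 3 uL/min
- compound 2 `CC(C)n1nc(-c2ccnc3[nH]c(C4CCN(CC(=O)N(C)C)CC4)cc23)ccc1=O`: 13 uL/min

In an ADME assay on microsomes from liver (Homo sapiens) for metabolic stability (on this read-out lower numbers stand for slow clearance and higher numbers for fast clearance), compound 1 gives < 3 uL/min, which is a limit of the assay and not a number. In this assay, among the measured compounds shown here, compound 2 gives 13 uL/min, the only numeric value among the two compounds measured so far. Compound 1 sits at the limit (the limit of < 3 uL/min in this assay, at which 1 of the 2 values shown sits). For the measured compounds named here, no step between two measured compounds that differ in a single place exists here, so the usual scatter is the only yardstick.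

Compound 3 `COc1cc(=O)n(C)cc1-c1ccnc2[nH]c(C3CCN(CC(=O)N(C)C)CC3)cc12` is not yet measured. It differs from compound 2 by a group of 10 heavy atoms (7 carbon, 1 nitrogen, 2 oxygen; one six-membered aromatic ring with 1 hetero atom) in place of a group of 10 heavy atoms (7 carbon, 2 nitrogen, 1 oxygen; one six-membered aromatic ring with 2 hetero atoms), on an aromatic carbon.

Going by the values given here, with no measured step to lean on, the expected step of a 1.4-fold lower number from compound 2 to compound 3 (0.16 log units; within the scatter) in this assay is taken as small, within or close to the scatter, with the direction uncertain. Compound 3 is therefore expected at about 9 uL/min in this assay, with a range from 3 uL/min to 25 uL/min.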

Compound 3, intrinsic clearance in a liver preparation (reported as CLH), per the amount of preparation that the assay uses: < 3 uL/min
Compound 3: a limit, no number; the forecaster's own chance of this, stated with the estimate: 25%; middle value at least 3.0-fold (0.47 log units) from the limit.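

In this assay, the first step readable in the series, on an aromatic carbon opposite the ring nitrogen, gives an at least 4.3-fold lower number from compound 2 to compound 3 (0.63 log units; beyond the scatter), so replacing the six-membered aromatic ring with 2 hetero atoms by the one with 1 hetero atom changes clearance by more than the usual scatter. Compound 3 gives < 3 uL/min, which is a limit and not a number, so the step has a lower bound and its full size cannot be read. Further falls in clearance from changes at this position would not show on this read-out: the limit of < 3 uL/min in this assay, at which 2 of the 3 values shown sit.

This single pair does not separate the loss of a ring nitrogen from the change in the groups carried on the ring. Also open, as far as these compounds go, is how clearance responds to a ring bearing an amine or a carboxylic acid at this place.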